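Acylsulfonamide series: sulfonyl substituent and passive permeability

The source may report more compounds than this note shows. Statements on the series, on what has been measured and on what is new or still open speak of the compounds shown alone.

Measured compounds:
compound 1 `O=C(NS(=O)(=O)c1ccccc1)c1ccc(Nc2nc(NC3(c4ccc(Cl)cc4)CC3)nc(OCC(F)(F)F)n2)cc1` — 182 nm/s
compound 2 `COC(=O)NCCS(=O)(=O)NC(=O)c1ccc(Nc2nc(NC3(c4ccc(Cl)cc4)CC3)nc(OCC(F)(F)F)n2)cc1` — 39 nm/s
compound 3 `CC(C)NC(=O)NCCS(=O)(=O)NC(=O)c1ccc(Nc2nc(NC3(c4ccc(Cl)cc4)CC3)nc(OCC(F)(F)F)n2)cc1` — 45 nm/s

In a physicochemical assay for permeability, using PAMPA, at pH 7.4 (on this read-out higher numbers stand for higher permeability and lower numbers for lower permeability), compound 1 gives 182 nm/s, the highest number of the three; compound 3 stands nearest to it and compound 2 furthest. Both measured steps away from compound 1 replace the phenyl on the sulfonyl sulfur with a two-carbon chain carrying a further group: a 4.7-fold lower number from compound 1 to compound 2 (0.67 log units; beyond the scatter) and a 4.0-fold lower number from compound 1 to compound 3 (0.61 log units; beyond the scatter). The two chain-bearing compounds differ only at the carbonyl carbon, and a 1.2-fold higher number from compound 2 to compound 3 (0.06 log units; within the scatter) shows that the exchange of isopropylamino for methoxy there does not move the read-out.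

Compound 4 `O=C(NS(=O)(=O)CCNCc1ccccc1)c1ccc(Nc2nc(NC3(c4ccc(Cl)cc4)CC3)nc(OCC(F)(F)F)n2)cc1` is the unmeasured member. Its change from compound 1 is 2-(benzylamino)ethyl in place of phenyl on a sulfonyl sulfur. Among the measured compounds shown here, this step resembles those to compounds 2 and 3 in that the phenyl on the sulfonyl sulfur leaves and a substituted ethyl chain enters; what enters here is 2-(benzylamino)ethyl, which no measured compound carries. For the measured compounds named here, the steps that bear on it are a 4.7-fold lower number from compound 1 to compound 2 (0.67 log units; beyond the scatter) and a 4.0-fold lower number from compound 1 to compound 3 (0.61 log units; beyond the scatter), both modest and both downward, beyond the scatter. A downward step of at least that size is therefore expected, with wide uncertainty since the entering group is new to the set. For compound 4 the expected step in this assay is a 7.3-fold lower number from compound 1 to compound 4 (0.86 log units; beyond the scatter), giving an estimate of 25 nm/s with a range of 6 nm/s to 90 nm/s.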

Compound 4, apparent permeability: 49 nm/s
Beside the measured number, compound 4's estimate is 2.0-fold (0.29 log units) below it; the range from low to high includes it.
By their numbers in this assay, from the lowest: compounds 2, 3 and 4 (each within the scatter of the next); then compound 1.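

In this assay, 2-(benzylamino)ethyl on the sulfonyl sulfur also gives a downward step, a 3.7-fold lower number from compound 1 to compound 4 (0.57 log units; beyond the scatter), even though this entering group keeps a six-membered aromatic ring of carbon only, as the departing phenyl did, so keeping such a ring within the new substituent does not hold the number at the level of compound 1. The group on the amine nitrogen of the chain is now seen to change three ways, and neither a 1.1-fold higher number from compound 3 to compound 4 (0.04 log units; within the scatter) nor a 1.3-fold higher number from compound 2 to compound 4 (0.10 log units; within the scatter) lies beyond the scatter, so benzyl, isopropylcarbamoyl and methoxycarbonyl at this place cannot be told apart on this read-out. No measured information on hand explains these steps.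

From the compounds shown here alone, all three chain compounds carry an amine nitrogen on the ethyl chain, so it remains open whether a plain ethyl or a longer all-carbon chain on the sulfonyl sulfur would give a step of the same size. Also open, going by these compounds, is how a carboxylic acid or a tertiary amine at the end of the chain would read in this assay, and whether a substituted phenyl would stay with compound 1 or with the chain compounds.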